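The compounds below may be only part of what the source reports. "The series", "measured", "known", "first", "only" and "open" are said of these compounds alone.

Measured compounds:
compound 2 `Nc1nc(-c2ccc(O)cc2)cn2c(=O)n(-c3ccccc3)nc12`, 53 nM
compound 3 `O=c1[nH]c(-c2ccccc2)cn2c(=O)n(-c3ccccc3)nc12`, 96 nM
compound 1 `C=CCOc1ccc(-c2cn3c(=O)n(-c4ccccc4)nc3c(N)n2)cc1`, "not determined" (no result reported) in an assay on cells for displacement of a labelled ligand from adenosine receptor A3 (Homo sapiens), read by scintillation counting, with a stated time of 3 h; on this read-out higher numbers stand for weaker inhibition and lower numbers for stronger inhibition

Compound 2 gives the lower of the two numbers in this assay, but its gap to compound 3 lies within the usual scatter, so the two cannot be ordered. Compound 1 has no number in this assay and offers no guidance. The unmeasured compound 4 `CCCOc1ccc(-c2cn3c(=O)n(-c4ccccc4)nc3c(N)n2)cc1` differs from compound 2 by propyl in place of hydrogen on an oxygen on an aromatic ring. Within the data shown here, no step between measured compounds is available, so the size of the change is uncertain; a small shift, weaker or unchanged rather than stronger, is expected. The step of a 1.5-fold higher number from compound 2 to compound 4 (0.18 log units; within the scatter) that this estimate means is expected to stay near the scatter. Compound 4 is therefore estimated at 80 nM, with a range from 20 nM to 320 nM.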

Compound 4, inhibition constant: > 30000 nM
Compound 4: a limit, no number (the forecaster's own chance of this, stated with the estimate: 5%); middle value at least 370-fold (2.57 log units) away from the limit.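

In this assay, among these compounds, propyl in place of hydrogen on an oxygen on an aromatic ring gives an at least 560-fold higher number from compound 2 to compound 4 (2.75 log units; beyond the scatter), so this oxygen proves to be a place where one change can cost far more than the scatter, which the earlier compounds could not show. For compound 4 the value is a limit and not a number, so the full size of the step stays unknown: the limit of > 30000 nM in this assay, at which 1 of the 4 values shown sits.

Going by these compounds, it remains open whether a methyl on this oxygen would behave like hydrogen or like propyl. Also open, on these data alone, is how an amine in place of the hydroxy would fare.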